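Bridged bicyclic amide acids: butyl to carboxypropyl

This account rests on a few compounds, and the source may have more. Where it says the series, first, only, none or still open, it means among the compounds named here.

Three amide acids on a shared bicyclic core have been measured in an ADME assay on HT-29 cells (Homo sapiens) for cytotoxicity, read by MTT assay, with a stated time of 72 h; a higher number here means a weaker inhibitor of growth, a lower number a stronger inhibitor of growth. Compound 1 `CCCCNC(=O)C1C(C(=O)O)[C@@H]2CC[C@H]1O2` carries a butyl amide and gives 10000 nM. Compound 2 `CCc1ccccc1NC(=O)C1C(C(=O)O)[C@@H]2CC[C@H]1O2`, with an aryl amide, gives 10000 nM in this assay. Compound 3 `C/C(=N/Nc1ccccc1)c1ccccc1NC(=O)C1C(C(=O)O)[C@@H]2CC[C@H]1O2`, with a larger aryl amide, gives 10000 nM in this assay. Compound 1 stands level with compound 2 and compound 3 at the digits shown; none of the three separates from the others beyond the usual scatter, so the series so far shows no spread at all.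

Compound 4 `O=C(O)CCCNC(=O)C1C(C(=O)O)[C@@H]2CC[C@H]1O2` is not yet measured. It differs from compound 1 as follows: carboxy in place of methyl on a saturated chain carbon, three bonds along the chain from an amide-type nitrogen. Among the measured compounds shown here, no step between measured compounds is available to calibrate this change, and the three measured values give no sign that the amide substituent moves the read-out within the range explored. The step from compound 1 to compound 4 is therefore expected to be no change at the digits printed from compound 1 to compound 4 (within the scatter), that is, nothing beyond the scatter. Compound 4 is expected to give 10000 nM in this assay, within 5000 nM to 20000 nM.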

Compound 4, concentration for 50% growth inhibition: 10000 nM
For compound 4 middle estimate and measured number coincide at the digits printed; the measured number falls inside the stated range.
By their numbers in this assay, from the lowest: compounds 1, 2, 3 and 4 (each within the scatter of the next).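

In this assay the series now has its first step between compounds that differ in one place, no change at the digits printed from compound 1 to compound 4 (within the scatter), for carboxy in place of methyl on a saturated chain carbon, three bonds along the chain from an amide-type nitrogen. The earlier compounds shown here differ in the whole amide substituent, whereas this step isolates a single change at the end of the butyl chain and shows no separation there. Nothing available here bears on why the read-out stays the same.

Going by these compounds, whether an amine, a hydroxyl group or a longer chain ending in a carboxylic acid at this place would separate from compound 1 remains open. All four compounds print the same value, so the shown compounds identify no structural change that moves the read-out.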